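A few compounds are considered here, and "the series" means these few. Any claim that something is new, unique, unknown or untested is made for them only; others in the source may bear on it.

Measured so far:
- compound 1 `Cn1c(-c2cccc(Cl)c2)nc2c(NC3CCCC3)ncnc21`: 2530 nM in a functional assay on CHO cells for antagonist activity at adenosine receptor A2b (Homo sapiens), read by 33P incorporation, with a stated time of 20 min; a higher number here means a weaker inhibitor, a lower number a stronger inhibitor
- compound 2 `CCCn1c(-c2ccccc2)nc2c(NC3CCC3)ncnc21`: 774 nM in this assay

Compound 1 stands at the higher of the two numbers in this assay, the weaker inhibitor; compound 2 lies lower, and the gap between the two is beyond the usual scatter. The two compounds differ in more than one place, so no single change can be read from that gap.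

Compound 3 `Cn1c(-c2cccnc2)nc2c(NC3CCCC3)ncnc21` is the next compound for this assay. It differs from compound 1 in one place: pyridin-3-yl in place of 3-chlorophenyl on an aromatic carbon. For the measured compounds named here, neither measured compound carries a pyridine at this position, so no measured pair shows what this exchange does. With that in mind a small step is expected, most likely toward a somewhat weaker inhibitor, and quite possibly not beyond the scatter. The expected step is a 1.4-fold higher number from compound 1 to compound 3 (0.14 log units; within the scatter). Compound 3 is expected to give 3500 nM, in a range from 1200 nM to 10000 nM.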

Compound 3, inhibition constant: > 30000 nM
Compound 3 ended at the assay's limit; the forecaster's own chance of this, stated with the estimate: 10%; middle value at least 8.5-fold (0.93 log units) from the limit.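

In this assay, pyridin-3-yl in place of 3-chlorophenyl gives an at least 11-fold higher number from compound 1 to compound 3 (1.07 log units; beyond the scatter), so the aromatic carbon between two ring nitrogen atoms is a place where the exchange of one six-membered aromatic ring for another can carry a large step. Compound 3 gives > 30000 nM, which is a limit of the assay and not a number. The step therefore fixes only a minimum size, and how far compound 3 lies from compound 1 remains unknown: the limit of > 30000 nM in this assay, at which 1 of the 3 values shown sits.

The exchange removes the chlorine and brings in the ring nitrogen together, so the compounds shown do not tell which of the two accounts for the step. A plain phenyl group on the core of compound 1 would separate the two, and pyridin-4-yl would show whether the place of the ring nitrogen matters.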